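Moving the methoxy group on the aryl thiosemicarbazone

The source may hold more compounds than are shown below. What is called first, only, known or untested is meant among the compounds shown, and "the series" means these compounds.

Measured compounds:
compound 1 `N#Cc1ccc(NC(=S)N/N=C/c2ccc3ccccc3n2)cc1` gives 23700 nM
compound 2 `COc1cccc(NC(=S)N/N=C/c2ccc3ccccc3n2)c1` gives 79400 nM

Both compounds were tested in a functional assay on SGC-7901 cells (Homo sapiens) for antiproliferative activity, read by sulforhodamine B assay, with a stated time of 72 h; a higher number here means a weaker inhibitor, a lower number a stronger inhibitor. Compound 2 stands highest of the two numbers shown; its nearest neighbour is compound 1, and the step of a 3.4-fold higher number from compound 1 to compound 2 (0.53 log units; beyond the scatter) is a modest one that lies beyond the scatter. Compound 3 `COc1ccc(NC(=S)N/N=C/c2ccc3ccccc3n2)cc1` has not yet been measured. It differs from compound 2 by 4-methoxyphenyl in place of 3-methoxyphenyl on an amide-type nitrogen. For the measured compounds named here, the one measured step, from compound 1 to compound 2, swaps a different group and so does not directly bear on this change; it only shows that an exchange on this nitrogen can shift the number modestly. For compound 3 a step of at most modest size in either direction, or none beyond the scatter, is therefore expected, written as a 1.6-fold lower number from compound 2 to compound 3 (0.20 log units; within the scatter). Compound 3 is estimated at 50000 nM, in the range 15000 nM to 160000 nM.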

Compound 3, half-maximal inhibitory concentration: 89600 nM
Beside the measured number, compound 3's estimate is 1.8-fold (0.25 log units) below it, and the stated range covers the measured number.
By their numbers in this assay, from the lowest: compound 1; then compounds 2 and 3 (each within the scatter of the next).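

In this assay, the step from the 3-methoxyphenyl group to the 4-methoxyphenyl group on the amide-type nitrogen gives a 1.1-fold higher number from compound 2 to compound 3 (0.05 log units; within the scatter) and so stays within the scatter; these two methoxyphenyl groups cannot be told apart here. The swap of methoxy in place of cyano on an aromatic carbon, a cleaner single change than the earlier one, gives a 3.8-fold higher number from compound 1 to compound 3 (0.58 log units; beyond the scatter) and shows a modest gap that lies beyond the scatter, with compound 1 holding the lower number of this pair. Nothing available explains why the numbers fall this way.

Still open, as far as these compounds go, is how an amine or a carboxylic acid in place of the methoxy or cyano group would read in this assay. Also open, from the compounds shown here alone, is whether ethoxy, a longer chain than methoxy, would leave the number where compound 3 has it.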